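Swapping hydroxy for dimethoxy on a growth-inhibiting series

A few compounds are considered here, and "the series" means these few. Any claim that something is new, unique, unknown or untested is made for them only; others in the source may bear on it.

Among the measured compounds shown here, in a functional assay on Gurav cells (Homo sapiens) for inhibition, read by sulforhodamine B assay (on this read-out higher numbers stand for weaker inhibition of growth and lower numbers for stronger inhibition of growth), compound 3 (`Oc1ccc(-c2ccc(-c3ccc(-c4nc5ccccc5[nH]4)cc3)cc2)cc1`) gives 100000 nM as the highest of the three numbers measured so far. Compound 2 (`FC(F)(F)c1ccc(-c2ccc(-c3ccc(-c4nc5ccccc5[nH]4)cc3)cc2)cc1`) carries trifluoromethyl where compound 3 carries hydroxy, and compound 2 gives 39100 nM in the same test, while compound 1 (`COc1ccc(-c2ccc(-c3ccc(-c4nc5cc(C)ccc5[nH]4)cc3)cc2)cc1OC`) gives 1310 nM as its result. Compound 4 (`COc1ccc(-c2ccc(-c3ccc(-c4nc5ccccc5[nH]4)cc3)cc2)cc1OC`) has not yet been measured. Its difference from compound 3 is counted here (3,4-dimethoxyphenyl in place of 4-hydroxyphenyl on an aromatic carbon) and amounts to 3,4-dimethoxyphenyl in place of 4-hydroxyphenyl on an aromatic carbon.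

For the measured compounds named here, only one measured step touches this place, namely a 2.6-fold higher number from compound 2 to compound 3 (0.41 log units; beyond the scatter) as a modest change beyond the scatter. It shows that the number responds to the group here, yet it involves no methoxy group. The closer guide is compound 1 at 1310 nM on this read-out, which already bears 3,4-dimethoxyphenyl but has an extra methyl on the core of compound 1. No measurement isolates that methyl, so the expected range stays wide. A large step toward a lower number is expected, stated as a 33-fold lower number from compound 3 to compound 4 (1.52 log units; beyond the scatter) in this estimate. For compound 4 the estimated value is 3000 nM with an expected range from 800 nM to 15000 nM in this assay once it is tested.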

Compound 4, concentration for 50% growth inhibition: 9230 nM
Beside the measured number, compound 4's estimate is 3.1-fold (0.49 log units) below it, and the stated range covers the measured number.
By their numbers in this assay, from the lowest: compound 1; then compound 4; then compound 2; then compound 3.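

Among the compounds shown here, replacing 4-hydroxyphenyl with 3,4-dimethoxyphenyl gives an 11-fold lower number from compound 3 to compound 4 (1.03 log units; beyond the scatter) in this assay, the first measured step at this position to involve methoxy groups and the first here to be rated large. Set against the trifluoromethyl-bearing group, the same 3,4-dimethoxyphenyl gives a 4.2-fold lower number from compound 2 to compound 4 (0.63 log units; beyond the scatter), so the three groups compared at this position now fall into a clear order, with 3,4-dimethoxyphenyl giving the strongest inhibition of growth and 4-hydroxyphenyl the weakest. For the compounds shown here, the result also isolates the methyl on the core for the first time: a 7.0-fold higher number from compound 1 to compound 4 (0.85 log units; beyond the scatter) shows that this second place affects the number too, so the low value of compound 1 cannot be credited to the 3,4-dimethoxyphenyl group alone.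

No evidence available here explains either the effect of the 3,4-dimethoxyphenyl group or that of the core methyl. The compounds shown leave open how a single methoxy group, an amine or a carboxylic acid would compare at this position, and whether the core methyl would produce a step of similar size alongside 4-hydroxyphenyl or the trifluoromethyl-bearing group.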